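Swapping a Pyridine for a Thiophene on a Shared Core

The source may hold more compounds than are shown below. What is called first, only, known or untested is meant among the compounds shown, and "the series" means these compounds.

Compound 1 `Cc1c(-c2ccccc2)sc(N)c1C(=O)c1ccc(Cl)cc1`: 1%
Compound 2 `Cc1sc(N)c(C(=O)c2ccc(Cl)cc2)c1-c1ccccc1`: 1%
Compound 3 `CC(C)(C)Cc1c(-c2ccncc2)sc(N)c1C(=O)c1ccc(Cl)cc1`: 1%

Of the compounds shown here, three sharing one core have been tested in an assay on CHO cells for displacement of a labelled ligand from adenosine receptor A1 (Homo sapiens), read by scintillation counting, tested at 10 uM; on this read-out lower numbers stand for less inhibition and higher numbers for more inhibition at the one concentration tested (going by the name of the read-out). Compound 1 gives 1% in this assay. Compound 2 gives 1%. Compound 3 gives 1%. All three values sit level with one another at the digits shown, and every gap between them falls within the usual scatter of repeated measurements, so no compound's number can be called higher or lower than another's. Compound 3 therefore stands where its two companions stand: at the floor of what this assay can resolve, with essentially no displacement of the labelled ligand at the single concentration tested.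

The next compound, compound 4 `CC(C)(C)Cc1c(-c2ccsc2)sc(N)c1C(=O)c1ccc(Cl)cc1`, differs from compound 3 in one place: thiophen-3-yl in place of pyridin-4-yl on an aromatic carbon. The neopentyl group, the amino group and the chlorinated benzoyl group are retained.

No comparable swap of a pendant aromatic ring has been measured here, so the size of the step can be judged only from the flat picture above. Compound 4 is expected to remain at the floor of the assay, with a step of a number 1 percentage points higher from compound 3 to compound 4 (within the scatter) that is estimated to lie within the scatter. The estimated value for compound 4 in this assay is 2%, with a likely range from -8% to 12%.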

Compound 4, a percentage reported as inhibition, at one concentration (the size of the read-out at that concentration, not a potency): 2%
Beside the measured number, compound 4's estimate shows no gap at the digits printed; the range from low to high includes it.
By their numbers in this assay, from the lowest: compounds 1, 2, 3 and 4 (each within the scatter of the next).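

Putting thiophen-3-yl in place of pyridin-4-yl on this aromatic carbon, next to the ring sulfur, gives a step of a number 1 percentage points higher from compound 3 to compound 4 (within the scatter) in this assay. For the compounds shown here, this is the first comparison here between two compounds that differ in only one place, so it is the first direct look at this position: with the neopentyl group, the amino group and the chlorinated benzoyl group held constant, exchanging a six-membered aromatic ring carrying a nitrogen for a five-membered one carrying a sulfur leaves the read-out where it was, within the scatter. No supporting data are available to explain this flat result.

With all four compounds this close together, the shown values cannot tell which parts of the structure matter for this receptor, since a change can only be seen once a compound gives a reading clear of the others. On these data alone, it remains open whether a carboxylic acid or a piperidine on this carbon, or a longer chain or a cyclohexyl group in place of the neopentyl, would give such a reading.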